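A Carbamoylpyridinyl Head Group in Place of a Carboxypyridinyl One

This account rests on a few compounds, and the source may have more. Where it says the series, first, only, none or still open, it means among the compounds named here.

compound 1: `N#Cc1cnc(C(O)CCCCCCc2ccccc2)o1` — 4200 nM
compound 2: `O=C(O)c1cccc(-c2cnc(C(O)CCCCCCc3ccccc3)o2)n1` — > 10000 nM

In an assay (Rattus norvegicus) for inhibition of Fatty-acid amide hydrolase 1 (Homo sapiens) (on this read-out lower numbers stand for stronger inhibition and higher numbers for weaker inhibition), compound 1 gives 4200 nM. For compound 2 this assay reports only a limit, > 10000 nM. From the compounds shown here alone, compound 2 therefore stands at the limit of > 10000 nM in this assay, at which 1 of the 2 values shown sits, so its true value is unknown beyond that. Among the measured compounds shown here, the one measured step, an at least 2.3-fold higher number from compound 1 to compound 2 (0.37 log units; beyond the scatter), is itself only a lower bound on the loss.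

Compound 3, `NC(=O)c1ccc(-c2cnc(C(O)CCCCCCc3ccccc3)o2)nc1`, differs from compound 2 by 5-carbamoylpyridin-2-yl in place of 6-carboxypyridin-2-yl on an aromatic carbon. For the measured compounds named here, no measured step compares these two pyridinyl groups with each other; the step from compound 1 to compound 2 shows only that a carboxypyridinyl group weakens inhibition relative to cyano. Compound 3 is expected to remain weak, with the step that the limit leaves unreadable from compound 2 to compound 3 estimated to lie within the scatter. Compound 3 is therefore estimated at 12000 nM, in the range 2500 nM to 60000 nM, and a limit is again likely.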

Compound 3, inhibition constant: 3000 nM
For compound 3 the middle estimate is 4.0-fold (0.60 log units) above the measured one; measured number inside the range.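

In this assay, the 5-carbamoylpyridin-2-yl group shows that a pyridinyl ring on this aromatic carbon, next to the ring oxygen, can keep measurable inhibition, with an at least 3.3-fold lower number from compound 2 to compound 3 (0.52 log units; beyond the scatter). This step is only a lower bound, because compound 2 carries a limit and not a number: the limit of > 10000 nM in this assay, at which 1 of the 3 values shown sits. Set against the cyano group, the same pyridinyl group gives a 1.4-fold lower number from compound 1 to compound 3 (0.15 log units; within the scatter), so compound 1 and compound 3 stand level, and the loss seen with compound 2 does not extend to every pyridinyl group at this position.

The step from the carboxypyridinyl to the carbamoylpyridinyl group changes both the group on the pyridine ring and its place there, and the compounds shown do not separate the two. From the compounds shown here alone, whether a 5-carboxypyridin-2-yl or a 6-carbamoylpyridin-2-yl group would behave like compound 3 or like compound 2 remains open.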